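The source may hold more compounds than are shown below. What is called first, only, known or untested is meant among the compounds shown, and "the series" means these compounds.

Three compounds have been measured in an assay on CHO cells for displacement of a labelled ligand from adenosine receptor A3 (Homo sapiens), read by scintillation counting, tested at 10 uM; a lower number here means less inhibition, a higher number more inhibition at the concentration tested (going by the name of the read-out):
compound 1 `CC(C)(C)Cc1c(-c2cccnc2)sc(N)c1C(=O)c1ccc(Cl)cc1`, 1%;
compound 2 `CC(C)(C)Cc1c(-c2cccc(F)c2F)sc(N)c1C(=O)c1ccc(Cl)cc1`, 1%;
compound 3 `CC(C)(C)Cc1c(-c2cc(F)ccc2F)sc(N)c1C(=O)c1ccc(Cl)cc1`, 1%.

Compound 3 stands level with compounds 1 and 2 at the digits shown: the step of no change at the digits printed from compound 1 to compound 3 (within the scatter) and the step of no change at the digits printed from compound 2 to compound 3 (within the scatter) both lie within the scatter, as does no change at the digits printed from compound 1 to compound 2 (within the scatter). Compound 4 `Cc1ccc(-c2sc(N)c(C(=O)c3ccc(Cl)cc3)c2CC(C)(C)C)cc1` has not yet been measured. It differs from compound 3 in one place: 4-methylphenyl in place of 2,5-difluorophenyl on an aromatic carbon. Among the compounds with values here, none of the measured steps carries this exact exchange, but all three swap the group on that same aromatic carbon of the shared core, and none moved the read-out beyond the scatter. Compound 4 is therefore expected to remain at the same low level, a step of a number 1 percentage points higher from compound 3 to compound 4 (within the scatter) in this assay. The estimate for compound 4 is 2%, with a range from 0% to 12%.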

Compound 4, a percentage reported as inhibition, at one concentration (the size of the read-out at that concentration, not a potency): 1%
The estimate for compound 4 lay 1 percentage points above the measured number, within the range that was stated.
By their numbers in this assay, from the lowest: compounds 1, 2, 3 and 4 (each within the scatter of the next).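

In this assay the exchange for 4-methylphenyl gives no change at the digits printed from compound 3 to compound 4 (within the scatter) and no change at the digits printed from compound 2 to compound 4 (within the scatter) and no change at the digits printed from compound 1 to compound 4 (within the scatter) on this aromatic carbon next to the ring sulfur. A methyl-bearing phenyl with no fluorine thus joins the two difluorophenyl groups and pyridin-3-yl, and none of the four groups separates from the others at this position. Nothing at hand explains this sameness.

As far as these compounds go, whether an amine or a carboxylic acid on this phenyl ring would move the read-out stays open. So does whether a longer chain in place of the neopentyl group would.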